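Removing the Carboxy Group from a Weak Binder

The compounds below may be only part of what the source reports. "The series", "measured", "known", "first", "only" and "open" are said of these compounds alone.

Two related compounds have been measured so far. Compound 1 `COc1cc(OC)c(NC(=O)Cn2nc(CC(=O)O)c3ccccc32)cc1Cl` and compound 2 `COc1cc(OC)c(NC(=O)Cc2cn(CC(=O)O)c3ccccc23)cc1Cl` share the same core and the same amide-linked aryl group, but differ in which part of the core carries the carboxymethyl chain and which carries the amide link. In an assay on membranes from CHO cells for displacement of a labelled ligand from sphingosine 1-phosphate receptor 2 (Homo sapiens) (on this read-out lower numbers stand for stronger inhibition and higher numbers for weaker inhibition), compound 1 gives 2010 nM, while compound 2 gives 10700 nM, the higher of the two numbers; its gap to compound 1 lies beyond the scatter of repeated measurements. Compound 3 `COc1cc(OC)c(NC(=O)Cc2cn(C)c3ccccc23)cc1Cl` has not been measured. It differs from compound 2 in one place: hydrogen in place of carboxy on a saturated chain carbon bound to an aromatic nitrogen, so that the carboxymethyl group on the aromatic nitrogen becomes a methyl group. Going by the values given here, no measured pair shows the effect of this change, so the size of the step can only be guessed. Compound 2 already stands at a weak level, and the change is expected to move the number by a small step, most likely toward weaker binding, with a real chance that the assay returns only a limit. Compound 3 is therefore expected to give 15000 nM, in the range 4000 nM to 50000 nM, which means an expected step of a 1.4-fold higher number from compound 2 to compound 3 (0.15 log units; within the scatter).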

Compound 3, half-maximal inhibitory concentration: 3790 nM
Estimate against measurement, compound 3: 4.0-fold (0.60 log units) above, and the stated range ends above it.
By their numbers in this assay, from the lowest: compounds 1 and 3 (each within the scatter of the next); then compound 2.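

In this assay, trading the carboxymethyl group on the aromatic nitrogen for a methyl group gives a 2.8-fold lower number from compound 2 to compound 3 (0.45 log units; beyond the scatter), so binding becomes modestly stronger when the carboxy group leaves. Going by these compounds alone, this is the first single-change comparison at this position, and it shows that the carboxy group on this chain is not required for a measured value in this assay. Nothing available explains the direction or the size of this step, which therefore stands as an observation without a known cause.

The compounds shown leave open whether the methyl group itself matters or whether the gain simply follows the loss of the carboxy group; an ethyl group, a longer chain or a chain ending in an amine in its place would help separate these two readings. They also leave open whether the same swap of carboxymethyl to methyl would move the number in the same direction on the core of compound 1, where the carboxymethyl chain and the amide link are arranged differently.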